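The source may hold more compounds than are shown below. What is called first, only, known or untested is meant among the compounds shown, and "the series" means these compounds.

Working notes on the series. In an ADME assay on L6 cells (Rattus norvegicus) for cytotoxicity (on this read-out higher numbers stand for weaker inhibition and lower numbers for stronger inhibition), compound 1 (`CCN(CC)c1ccc(NC2=NCCN2)cc1`) gives > 444000 nM, which is a limit of the assay and not a number. Compound 2 (`c1cc(NC2=NCCN2)ccc1CCc1ccc(NC2=NCCN2)cc1`) gives 34900 nM and compound 3 (`c1cc(NC2=NCCN2)ccc1Cc1ccc(NC2=NCCN2)cc1`) gives 63600 nM, two values within the usual scatter of each other. Compound 4 (`c1cc(N2CCCCC2)ccc1NC1=NCCN1`) has piperidin-1-yl in place of diethylamino on an aromatic carbon of the core of compound 1: piperidin-1-yl in place of diethylamino on an aromatic carbon. Within the data shown here, no measured pair sizes this change, so the expectation is loose. The expected step in this assay is modest and towards stronger inhibition: an at least 2.0-fold lower number from compound 1 to compound 4 (0.30 log units; that floor lies within the scatter). A reading that again reaches the limit would not be surprising. For compound 4 the estimated value is 220000 nM, with an expected range of 80000 nM to 444000 nM.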

Compound 4, half-maximal inhibitory concentration: > 283000 nM
Compound 4: a limit, no number; the forecaster's own chance of this, stated with the estimate: 40%; middle value at least 1.2-fold (0.10 log units) away from the limit.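

Among these compounds, no step from compound 1 to compound 4 can be read in this assay, as both results are limits and not numbers. The compounds shown leave open whether piperidin-1-yl in place of diethylamino on an aromatic carbon changes the read-out at all.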